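Methyl for Methoxy on the Aromatic Ring of Compound 2

The source may hold more compounds than are shown below. What is called first, only, known or untested is meant among the compounds shown, and "the series" means these compounds.

In an ADME assay on H9c2 cells (Rattus norvegicus) for cytotoxicity, read by MTT assay, with a stated time of 48 h (on this read-out lower numbers stand for stronger inhibition and higher numbers for weaker inhibition), compound 1 `O=C(NCCOC(=S)Nc1ccccc1)c1cccnc1` gives > 800000 nM, which is a limit of the assay. For the measured compounds named here, compound 2 `COc1ccc(NC(=S)OCCNC(=O)c2cccnc2)cc1` gives 695000 nM, the only actual number so far. Compound 3 `Cc1ccc(NC(=S)OCCNC(=O)c2cccnc2)cc1` carries methyl in place of methoxy on an aromatic carbon, para to a large group: methyl in place of methoxy on an aromatic carbon. Going by the values given here, one measured step bears on this change, an at least 1.1-fold lower number from compound 1 to compound 2 (0.06 log units; that floor lies within the scatter), and its size is only a floor, as the limit of > 800000 nM in this assay, at which 1 of the 2 values shown sits, shows. The expected step of a 1.0-fold higher number from compound 2 to compound 3 (0.00 log units; within the scatter) is therefore estimated to stay within the scatter. For compound 3 the estimate is 700000 nM, with an expected range from 400000 nM to 1200000 nM.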

Compound 3, half-maximal inhibitory concentration: 726000 nM
Estimate against measurement, compound 3: 1.0-fold (0.02 log units) below, and the stated range covers the measured number.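

In this assay, methyl in place of methoxy on this aromatic carbon, para to a large group, gives a 1.0-fold higher number from compound 2 to compound 3 (0.02 log units; within the scatter), so the two groups cannot be told apart here. For the compounds shown here, this is the first step at this position with an actual number at both ends, so it has a size and not only a floor. The other new step, an at least 1.1-fold lower number from compound 1 to compound 3 (0.04 log units; that floor lies within the scatter), cannot be read for size, because it rests on a limit: the limit of > 800000 nM in this assay, at which 1 of the 3 values shown sits.

The compounds shown leave open whether an amine or a carboxylic acid on this aromatic carbon would move the number beyond the scatter. They also leave open whether a longer chain there would do so.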